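Volume of distribution notes on compounds 1 to 3

The source may hold more compounds than are shown below. What is called first, only, known or untested is meant among the compounds shown, and "the series" means these compounds.

Among the compounds with values here, compound 1 `CCCC[C@H](NC(=O)O[C@H](Cn1cnc(-c2ccc(C(F)(F)F)cc2)c1)C(C)(C)C)C(=O)C(=O)Nc1ccn[nH]1` and compound 2 `CCCC[C@H](NC(=O)O[C@H](Cn1ccc(-c2ccc(C(F)(F)F)cc2)n1)C(C)(C)C)C(=O)C(=O)Nc1ccccn1` share a common core and differ from each other in more than one place, so no single step between them is counted. In an in vivo ADME assay on the whole organism (Rattus norvegicus) for pharmacokinetics (a lower number here means that more of the compound stays in the plasma, a higher number that more of the compound sits outside the plasma), compound 1 gives 2.4 L/kg. In this assay, within the data shown here, compound 2 gives 1.8 L/kg; the two numbers lie within the usual scatter of each other, so no order between compound 1 and compound 2 can be read, and there are no further measured compounds against which compound 2 could be placed. Compound 3 `CCCC[C@H](NC(=O)O[C@H](Cn1ccc(-c2ccc(C(F)(F)F)cc2)n1)C(C)(C)C)C(=O)C(=O)NCc1ccno1` has not yet been measured in this assay. It differs from compound 2 in one place: (1,2-oxazol-5-yl)methyl in place of pyridin-2-yl on an amide-type nitrogen. Among the measured compounds shown here, no step between measured compounds in this assay covers an exchange of this kind, so there is no measured basis for a direction. The expected step from compound 2 to compound 3 is no change at the digits printed from compound 2 to compound 3 (within the scatter), which amounts to no step beyond the scatter. For compound 3 the estimate in this assay is 1.8 L/kg, with a range from 1 L/kg to 3.2 L/kg.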

Compound 3, volume of distribution at steady state: 1.7 L/kg
Estimate against measurement, compound 3: 1.1-fold (0.02 log units) above; low and high end bracket the measured number.
By their numbers in this assay, from the lowest: compounds 3, 2 and 1 (each within the scatter of the next).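

In this assay, within the data shown here, the exchange of pyridin-2-yl for (1,2-oxazol-5-yl)methyl on the amide-type nitrogen gives a 1.1-fold lower number from compound 2 to compound 3 (0.02 log units; within the scatter) and is the first single-place step. At this position, a six-membered aromatic ring with 1 hetero atom can therefore be exchanged for a five-membered aromatic ring with 2 hetero atoms, carried on a methyl group, with no difference beyond the scatter, even though the two groups also differ in their count of hydrogen-bond acceptors. No measured property of these compounds accounts for this result.

The step covers only two uncharged groups without hydrogen-bond donors, so the compounds shown leave open whether an aminoalkyl group or a carboxylic acid on the same amide-type nitrogen would also stay within the scatter of compound 2. The group on that nitrogen in compound 1 also remains unresolved, as compound 1 differs from compound 2 in more than one place and its effect cannot be separated from the other difference.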